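Amine replacement on the shared core: notes toward compound 4

This account rests on a few compounds, and the source may have more. Where it says the series, first, only, none or still open, it means among the compounds named here.

Three compounds on the shared core have been run in a functional assay on PC-3 cells (Homo sapiens) for cytotoxicity, read by MTT assay, with a stated time of 72 h; on this read-out lower numbers stand for stronger inhibition and higher numbers for weaker inhibition. Compound 1 `O=S(=O)(c1ccccc1)c1nc2ccccc2nc1N1CCc2ccccc2C1` gives 5010 nM. Compound 2 `Cc1ccc(S(=O)(=O)c2nc3ccccc3nc2N2CCc3ccccc3C2)cc1` gives 22400 nM, and compound 3 `O=S(=O)(c1ccc(F)cc1)c1nc2ccccc2nc1N1CCc2ccccc2C1` gives 9230 nM. The measured steps all concern the substituent on the aryl ring of the sulfonyl group: a 4.5-fold higher number from compound 1 to compound 2 (0.65 log units; beyond the scatter), a 1.8-fold higher number from compound 1 to compound 3 (0.27 log units; within the scatter) and a 2.4-fold lower number from compound 2 to compound 3 (0.39 log units; beyond the scatter). On these numbers compound 3 holds the second highest of the three, close to compound 1 and separated from compound 2.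

Compound 4 `O=S(=O)(c1ccc(F)cc1)c1nc2ccccc2nc1N1CCC(O)CC1` differs from compound 3 in a different place: 4-hydroxypiperidin-1-yl in place of 1,2,3,4-tetrahydroisoquinolin-2-yl on an aromatic carbon. Within the data shown here, none of the measured steps touches the amine on the shared core; each alters only the aryl ring of the sulfonyl group. Among the measured compounds shown here, no measured step therefore gives a size for this change, and the direction has to be taken as open. The working expectation is that the number in this assay for compound 4 moves upward rather than downward, but with wide bounds. For compound 4 the estimate is 20000 nM, with a range from 5000 nM to 80000 nM. That estimate corresponds to an expected 2.2-fold higher number from compound 3 to compound 4 (0.34 log units; beyond the scatter), a step that a single measurement could easily fail to show.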

Compound 4, half-maximal inhibitory concentration: 2010 nM
Beside the measured number, compound 4's estimate is 10-fold (1.00 log units) above it, outside the stated range (below it).
By their numbers in this assay, from the lowest: compound 4; then compounds 1 and 3 (each within the scatter of the next); then compound 2.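

The amine on the shared core proves to be a place where this assay responds, with a 4.6-fold lower number from compound 3 to compound 4 (0.66 log units; beyond the scatter) as 4-hydroxypiperidin-1-yl replaces 1,2,3,4-tetrahydroisoquinolin-2-yl on an aromatic carbon, and the direction, left open by the aryl steps on the sulfonyl group, is now settled for this one pair. The exchange alters several features at once: the six-membered aromatic ring of carbon only leaves, while a hydroxyl oxygen and a hydrogen-bond donor enter, so this single step cannot assign the lower number to any one of them. No supporting measurement bears on why the number falls at this place.

Still open, on these data alone, is which feature carries the step, a question that an unsubstituted piperidin-1-yl, a 4-methoxypiperidin-1-yl or a morpholine at the same place would help to separate. Among these compounds, also open is whether the same amine exchange gives a step of similar size and direction with the unsubstituted phenyl of compound 1 or the 4-methylphenyl of compound 2 on the sulfonyl group, since the only reading at this place has the 4-fluorophenyl group.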